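Methyl for chloro on the aryl ring of compound 3

A few compounds are considered here, and "the series" means these few. Any claim that something is new, unique, unknown or untested is made for them only; others in the source may bear on it.

Measured so far:
- compound 1 `COc1ccc(-c2nn(-c3ccccc3)cc2CNc2ccc(F)cc2)cc1`: 6580 nM
- compound 2 `COc1ccc(-c2nn(-c3ccccc3)cc2CNc2ccc(C)cc2)cc1`: 8380 nM
- compound 3 `Clc1ccc(NCc2cn(-c3ccccc3)nc2-c2ccc(Cl)cc2)cc1`: 2450 nM

In a functional assay on B16-F10 cells (Mus musculus) for antiproliferative activity, read by MTT assay, with a stated time of 48 h (on this read-out lower numbers stand for stronger inhibition and higher numbers for weaker inhibition), compound 3 gives the lowest of the three numbers, beyond the scatter from both compound 1 and compound 2. Compound 1 and compound 2 differ only on the aniline side, and that step, a 1.3-fold higher number from compound 1 to compound 2 (0.11 log units; within the scatter), lies within the scatter. Compound 3 carries chloro on both aromatic rings, and its gap to compound 1 and compound 2 cannot be split between the two rings on the data shown.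

Compound 4 `Cc1ccc(-c2nn(-c3ccccc3)cc2CNc2ccc(Cl)cc2)cc1` keeps the aniline-side chloro of compound 3 and changes the other ring: methyl in place of chloro on an aromatic carbon. For the measured compounds named here, no measured step covers this position; the one measured step, between compound 1 and compound 2, touches the other ring and was within the scatter, so it bears only indirectly. With no direct guide, the expectation for compound 4 is a step of a 1.4-fold higher number from compound 3 to compound 4 (0.15 log units; within the scatter) in this assay, small and possibly not beyond the scatter, leaning toward a higher number. Compound 4 is therefore estimated at 3500 nM, between 1500 nM and 8500 nM.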

Compound 4, half-maximal inhibitory concentration: 6010 nM
For compound 4 the middle estimate is 1.7-fold (0.23 log units) below the measured one, within the range that was stated.
By their numbers in this assay, from the lowest: compound 3; then compounds 4, 1 and 2 (each within the scatter of the next).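

In this assay, the change from 4-chlorophenyl to 4-methylphenyl, with the aniline-side chloro held fixed, gives a 2.5-fold higher number from compound 3 to compound 4 (0.39 log units; beyond the scatter). For the compounds shown here, this is the first step read directly at this position, and it lies beyond the scatter, whereas the only earlier step, on the aniline ring, stayed within it. The low number of compound 3 therefore depends at least in part on the chloro on this ring, and nothing at hand says why the methyl gives a higher number here.

Whether this step keeps its size with a fluoro or a methyl on the aniline ring remains open, since it has been read only with the aniline-side chloro in place, and the share of that aniline-side chloro in the number of compound 3 has no single-change comparison in the compounds shown. Also open, on these data alone, is how far this position tolerates other groups: a bromo or a trifluoromethyl could show whether anything goes lower than chloro, and an amine or a carboxylic acid would test a very different kind of substituent on the same carbon.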